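Extending a Carbamate Side Chain in a Kinase Inhibitor Pair

The source may report more compounds than this note shows. Statements on the series, on what has been measured and on what is new or still open speak of the compounds shown alone.

For the measured compounds named here, compound 1 `CC(C)COC(=O)N1CCN(C(=O)c2nc(Nc3cc(C4CC4)[nH]n3)c3cc(Cl)ccc3n2)C[C@H]1C` is one of two compounds measured in an assay for inhibition of serine/threonine-protein kinase PAK 4 (Homo sapiens), read by FRET and Z'-LYTE, with a stated time of 60 min, tested at 0.5 uM, in the presence of a further agent that is not named here; on this read-out higher numbers stand for a stronger effect at the one concentration tested and lower numbers for a weaker effect. In this assay compound 1 gives 0.8%, the lowest of the two numbers recorded. Its nearest neighbour is compound 2 `CC(C)C(=O)OCOC(=O)N1CCN(C(=O)c2nc(Nc3cc(C4CC4)[nH]n3)c3cc(Cl)ccc3n2)C[C@H]1C`, which in this assay gives 16.4%. The change between them, (isopropylcarbonyl)oxy in place of isopropyl on a saturated chain carbon bound to an oxygen next to a carbonyl group, brought a number 15.6 percentage points higher from compound 1 to compound 2 (beyond the scatter). Compound 3 `C[C@@H]1CN(C(=O)c2nc(Nc3cc(C4CC4)[nH]n3)c3cc(Cl)ccc3n2)CCN1C(=O)OCOC(=O)C(C)(C)C` differs from compound 1 by ((tert-butyl)carbonyl)oxy in place of isopropyl on a saturated chain carbon bound to an oxygen next to a carbonyl group. Going by the values given here, this change matches the one between compound 1 and compound 2 in kind and in place, and that single step is the only measured one that bears on it, so a modest rise beyond the scatter is expected, a number 12.2 percentage points higher from compound 1 to compound 3 (beyond the scatter). Compound 3 is therefore estimated to give 13% in this assay, within a range from 0% to 30%.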

Compound 3, a percentage reported as inhibition, at one concentration (the size of the read-out at that concentration, not a potency): 0.7%
Compound 3: middle estimate off by 12.3 percentage points, on the high side, within the range that was stated.
By their numbers in this assay, from the lowest: compounds 3 and 1 (each within the scatter of the next); then compound 2.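

In this assay, ((tert-butyl)carbonyl)oxy in place of isopropyl gave a number 0.1 percentage points lower from compound 1 to compound 3 (within the scatter), so the entering ester unit at this place does not bring a rise on its own. A single methyl in place of hydrogen on a saturated chain carbon bound to a carbonyl carbon and two saturated chain carbons gave a number 15.7 percentage points lower from compound 2 to compound 3 (beyond the scatter), which shows that among these three compounds the reading depends on the outer end of the side chain, with only compound 2 standing apart. Nothing given here accounts for this difference.

The compounds shown leave open how an acetyl or a cyclopropylcarbonyl ending, or a longer chain between the two oxygens, would read at this place. They also leave open whether a carboxylic acid or an amine at the chain end would depart from compound 2 or from compound 3.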